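The source may hold more compounds than are shown below. What is called first, only, known or untested is meant among the compounds shown, and "the series" means these compounds.

Measured so far in an ADME assay on HepG2 cells (Homo sapiens) for cytotoxicity, with a stated time of 48 h; on this read-out lower numbers stand for stronger inhibition and higher numbers for weaker inhibition:

compound 1, `Cc1cc(C)cc(NC(=O)Cn2ccc(=O)c3ccccc32)c1` — 63100 nM
compound 2, `Cc1cc(C)cc(NC(=O)COc2ccnc3ccccc23)c1` — the value recorded for compound 2 is a limit of the assay, > 100000 nM
compound 3, `COc1ccc2nccc(OCC(=O)Nc3cc(C)cc(C)c3)c2c1` — 50100 nM

Compound 1 and compound 3 carry the same aryl amide side, but their cores differ; the difference between the two cores of compound 1 and compound 2 is not broken down here. Compound 1 and compound 3 stand close together in this assay, and the gap between them is within the usual scatter, so no order can be read from it.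

Within the core of compound 2, one change has been measured: methoxy in place of hydrogen on an aromatic carbon. It gave an at least 1.9-fold lower number from compound 2 to compound 3 (0.30 log units; that floor lies within the scatter), a step whose floor rests on the limit recorded for compound 2, (the limit of > 100000 nM in this assay, at which 1 of the 3 values shown sits), and which may therefore be larger than its floor states.

Not yet measured is compound 4, `COc1ccc2c(c1)c(=O)ccn2CC(=O)Nc1cc(C)cc(C)c1`. For the measured compounds named here, it is made from compound 1 by methoxy in place of hydrogen on an aromatic carbon, the same change as the one from compound 2 to compound 3, set in the same kind of place on a different core. Going by the values given here, the expected step in this assay is a 1.6-fold lower number from compound 1 to compound 4 (0.20 log units; within the scatter), resting on the one measured step of this change, an at least 1.9-fold lower number from compound 2 to compound 3 (0.30 log units; that floor lies within the scatter), and on the value of compound 1, 63100 nM. For compound 4 the estimate in this assay is 40000 nM, expected to fall between 18000 nM and 100000 nM.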

Compound 4, half-maximal inhibitory concentration in the HepG2 assay: > 100000 nM
Compound 4: a limit, no number; the forecaster's own chance of this, stated with the estimate: 15%; at least 2.5-fold (0.39 log units) between middle value and limit.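

In the HepG2 assay methoxy in place of hydrogen on an aromatic carbon gives an at least 1.5-fold higher number from compound 1 to compound 4 (0.19 log units; that floor lies within the scatter) on the core of compound 1. In the HepG2 assay compound 4 gives > 100000 nM, which is a limit of the assay, not a number. Set beside the earlier step, the change does not carry over in direction from one core to the other, since the number falls on one core and rises on the other: the same change on two cores in the HepG2 assay, an at least 1.9-fold lower number (0.30 log units; that floor lies within the scatter) from compound 2 to compound 3 and an at least 1.5-fold higher number (0.19 log units; that floor lies within the scatter) from compound 1 to compound 4, at least 3.1-fold (0.50 log units) apart, beyond the scatter of two such steps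
The true size of either step is not shown, and two pairs give no general rule for the series, as each step is only a floor resting on a limit: the limit of > 100000 nM in the HepG2 assay, at which 2 of the 4 values shown sit.

Left open is whether another group on the same aromatic carbon, such as an amine or a chlorine atom, would also move in opposite directions on the two cores. In a physicochemical assay for lipophilicity, at pH 7.4 (a higher number here means a more lipophilic compound, a lower number a more polar compound), compound 1 gives 3.54 and compound 4 gives 3.72. In the physicochemical assay the same change gives a number 0.18 log units higher from compound 1 to compound 4 (within the scatter) on the core of compound 1 only, so the compounds shown offer no link between that read-out and the split between the cores.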